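The source may hold more compounds than are shown below. What is called first, only, known or untested is meant among the compounds shown, and "the series" means these compounds.

Compound 1, `CCCCc1c(OC)nc2nc(C(=O)c3ccccc3)cn2c1C`: 2 mg/kg
Compound 2, `CCc1c(OC)nc2nc(C(=O)c3ccccc3)cn2c1C`: 2 mg/kg

Both compounds were tested in a functional assay on the whole organism with Rattus norvegicus as the target; on this read-out lower numbers stand for an effect already at smaller amounts and higher numbers for an effect only at larger amounts of compound. In this assay compound 1 gives 2 mg/kg and compound 2 gives 2 mg/kg, so compound 2 stands level with compound 1 at the digits shown. For the measured compounds named here, the one measured step, no change at the digits printed from compound 1 to compound 2 (within the scatter), shortened the chain on the saturated carbon and left the read-out unchanged within the scatter.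

Compound 3, `CCCc1c(OC)nc2nc(C(=O)c3ccccc3)cn2c1C`, has not yet been measured. It differs from compound 2 by methyl in place of hydrogen on a saturated chain carbon, two bonds along the chain from an aromatic carbon, which lengthens the same chain to a size between those of compound 2 and compound 1. Since the step from compound 1 to compound 2 bears directly on this change and was no change at the digits printed from compound 1 to compound 2 (within the scatter), no step beyond the scatter is expected in this assay. The expected step is no change at the digits printed from compound 2 to compound 3 (within the scatter). Compound 3 is therefore estimated at 2 mg/kg, with a range from 1 mg/kg to 4 mg/kg.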

Compound 3, minimum effective dose: 5 mg/kg
Compound 3: middle estimate off by 2.5-fold (0.40 log units), on the low side, outside the stated range (above it).
By their numbers in this assay, from the lowest: compounds 1 and 2 (each within the scatter of the next); then compound 3.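

This position does not respond to chain length in a steady way. In this assay, extending the ethyl chain of compound 2 to the propyl chain gives a 2.5-fold higher number from compound 2 to compound 3 (0.40 log units; beyond the scatter), and shortening the butyl chain by one methyl gives a 2.5-fold higher number from compound 1 to compound 3 (0.40 log units; beyond the scatter), so more compound is needed with the propyl chain than with either the shorter or the longer chain, although both steps are modest. Nothing available here accounts for this dip at the middle chain length.

The compounds shown leave open whether the propyl result marks a real feature of this position or a modest fluctuation in a whole-animal read-out. They also leave open how a methyl group, a pentyl chain, a branched isopropyl group or an amine at the end of the chain would behave here.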